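Aliphatic Ring in Place of Phenyl in a Cytotoxicity Series

The source may hold more compounds than are shown below. What is called first, only, known or untested is meant among the compounds shown, and "the series" means these compounds.

Of the compounds shown here, three sharing one core have been measured in an ADME assay on HepG2 cells (Homo sapiens) for cytotoxicity, read by luminescence, CellTiter-Glo and ATP content, with a stated time of 72 h; on this read-out higher numbers stand for an effect only at larger amounts of compound and lower numbers for an effect already at smaller amounts. Compound 1 `COc1ccc(F)cc1CNCCCNc1ccnc2cc(CCC(C)C)ccc12` gives 890 nM. Compound 2 `COc1ccc(F)cc1CNCCCNc1ccnc2cc(Oc3ccc(C(C)(C)C)cc3)ccc12` gives 7200 nM, and compound 3 `COc1ccc(F)cc1CNCCCNc1ccnc2cc(-c3ccccc3)ccc12` gives 2960 nM. Compound 3 therefore holds the second highest of the three numbers: the step of a 2.4-fold lower number from compound 2 to compound 3 (0.39 log units; beyond the scatter) separates it from compound 2, and the step of a 3.3-fold higher number from compound 1 to compound 3 (0.52 log units; beyond the scatter) separates it from compound 1.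

Compound 4 `COc1ccc(F)cc1CNCCCNc1ccnc2cc(CC3CCCCC3)ccc12` is not yet measured. It differs from compound 3 in one place: cyclohexylmethyl in place of phenyl on an aromatic carbon. Within the data shown here, the steps that bear on this change are a 3.3-fold higher number from compound 1 to compound 3 (0.52 log units; beyond the scatter) and an 8.1-fold higher number from compound 1 to compound 2 (0.91 log units; beyond the scatter), both modest, both beyond the scatter, and both leading away from compound 1, whose isopentyl group, like the entering cyclohexylmethyl, carries no aromatic ring. Because a 3.3-fold higher number from compound 1 to compound 3 (0.52 log units; beyond the scatter) ran upward when phenyl entered, compound 4 is expected to step back in this assay by about a 2.0-fold lower number from compound 3 to compound 4 (0.30 log units; within the scatter). The estimate for compound 4 is 1500 nM, with a range from 600 nM to 4000 nM.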

Compound 4, half-maximal effective concentration: 1830 nM
The estimate for compound 4 lay 1.2-fold (0.09 log units) below the measured number; low and high end bracket the measured number.
By their numbers in this assay, from the lowest: compound 1; then compounds 4 and 3 (each within the scatter of the next); then compound 2.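

In this assay, the change from an aromatic to a non-aromatic six-membered ring, with cyclohexylmethyl in place of phenyl, gives a 1.6-fold lower number from compound 3 to compound 4 (0.21 log units; within the scatter), so this replacement on the aromatic carbon is not separated from the scatter. Losing the aromatic ring from the group does not by itself return the number to that of the isopentyl group: the comparison with the open chain shows a 2.1-fold higher number from compound 1 to compound 4 (0.31 log units; beyond the scatter), although neither group carries an aromatic ring. The cyclohexylmethyl group also stands clear of the larger 4-(tert-butyl)phenoxy group, with a 3.9-fold lower number from compound 2 to compound 4 (0.59 log units; beyond the scatter).

The compounds shown leave open how an amine, a carboxylic acid or a longer chain at this position would read in this assay. Nothing available gives a reason for any of these steps.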